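A few compounds are considered here, and "the series" means these few. Any claim that something is new, unique, unknown or untested is made for them only; others in the source may bear on it.

Compound 2, `NC(=O)c1cccc(NC(=O)N2CCC(Oc3ccccc3Cl)CC2)c1`, carries a hydrogen on an amide-type nitrogen. Going by the values given here, in an assay on isolated protein for inhibition of acyl-CoA desaturase 1 (Mus musculus) (on this read-out lower numbers stand for stronger inhibition and higher numbers for weaker inhibition), compound 2 gives 10 nM, the only plain number among the two values in hand. Compound 1, `CNC(=O)c1cccc(NC(=O)N2CCC(Oc3ccccc3Cl)CC2)c1`, gives < 4 nM, which is a limit of the assay rather than a number. Among the compounds with values here, the one measured change on that nitrogen is an at least 2.5-fold higher number from compound 1 to compound 2 (0.39 log units; beyond the scatter), and its size is bounded by the limit of < 4 nM in this assay, at which 1 of the 2 values shown sits. Compound 3, `CC(C)(C)NC(=O)c1cccc(NC(=O)N2CCC(Oc3ccccc3Cl)CC2)c1`, differs from compound 2 by tert-butyl in place of hydrogen on an amide-type nitrogen. In the measured step a carbon group on that nitrogen went with the lower number. A modest fall is therefore expected for compound 3, a step of a 1.7-fold lower number from compound 2 to compound 3 (0.22 log units; within the scatter). Compound 3 is estimated at 6 nM, within 2 nM to 25 nM.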

Compound 3, half-maximal inhibitory concentration: > 10000 nM
Compound 3 gave a limit, no number; the forecaster's own chance of this, stated with the estimate: 25%; middle value at least 1600-fold (3.22 log units) away from the limit.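

Putting tert-butyl on this amide nitrogen brings an at least 1000-fold higher number from compound 2 to compound 3 (3.00 log units; beyond the scatter), and replacing methyl with it brings an at least 2500-fold higher number from compound 1 to compound 3 (3.39 log units; beyond the scatter). A carbon group here therefore does not simply go with the lower number: compared with hydrogen, methyl and tert-butyl move the read-out in opposite directions. Compound 3 gives a limit, not a number, so both steps show only a minimum size: the limit of > 10000 nM in this assay, at which 1 of the 3 values shown sits.

The compounds shown leave open where between methyl and tert-butyl the loss sets in. Ethyl or isopropyl on this nitrogen would help to place it.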